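This account rests on a few compounds, and the source may have more. Where it says the series, first, only, none or still open, it means among the compounds named here.

Compound 2, `CCC(=O)N1N=C(C)CC1c1cc(Br)ccc1O`, stands second highest of the three numbers measured in a functional assay on PC-3 cells (Homo sapiens) for cytotoxicity, read by MTT assay, with a stated time of 48 h (on this read-out higher numbers stand for weaker inhibition and lower numbers for stronger inhibition), where compound 2 gives 37800 nM. Its nearest neighbour is compound 3, `CC1=NN(C(=O)c2ccc(C)cc2)C(c2cc(Br)ccc2O)C1`, which in this assay gives 41200 nM; the step from compound 2 to compound 3 is a 1.1-fold higher number from compound 2 to compound 3 (0.04 log units; within the scatter). Furthest away is compound 1, `CC1=NN(C(=O)CCl)C(c2cc(Br)ccc2O)C1`, which gives 8890 nM in this assay; the step from compound 1 to compound 2 is a 4.3-fold higher number from compound 1 to compound 2 (0.63 log units; beyond the scatter), and from compound 1 to compound 3 it is a 4.6-fold higher number from compound 1 to compound 3 (0.67 log units; beyond the scatter).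

Compound 4, `CC1=NN(C(=O)COc2ccc(Cl)cc2)C(c2cc(Br)ccc2O)C1`, differs from compound 2 in one place: 4-chlorophenoxy in place of methyl on a saturated chain carbon bound to a carbonyl carbon. The step that bears most directly on this change is the one at the same saturated chain carbon, from compound 1 to compound 2, which was modest and beyond the scatter; the step from compound 2 to compound 3, where the acyl group was enlarged, stayed within the scatter. On that basis only a small step is expected for compound 4 in this assay, and it is estimated as a 1.7-fold lower number from compound 2 to compound 4 (0.24 log units; within the scatter) toward lower numbers. Compound 4 is therefore estimated at 22000 nM, within a range from 6000 nM to 80000 nM.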

Compound 4, half-maximal inhibitory concentration: 49000 nM
The estimate for compound 4 lay 2.2-fold (0.35 log units) below the measured number, and the stated range covers the measured number.
By their numbers in this assay, from the lowest: compound 1; then compounds 2, 3 and 4 (each within the scatter of the next).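

In this assay, 4-chlorophenoxy in place of methyl on a saturated chain carbon bound to a carbonyl carbon gives a 1.3-fold higher number from compound 2 to compound 4 (0.11 log units; within the scatter), so even a much larger group carrying an aromatic ring stands within the scatter of the methyl at this place. Measured against chloro at the same carbon, the same group gives a 5.5-fold higher number from compound 1 to compound 4 (0.74 log units; beyond the scatter), and chloro remains the only group shown at this carbon that sets its compound apart from the others. No measurement shown here accounts for these results.

The compounds shown leave open whether bromo, an amine or a longer chain on this carbon would stand with compound 1 or with compound 2 and compound 4. They also leave open how an unsubstituted phenoxy would read at this place.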